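Swapping trifluoromethyl for tert-butyl on a kinase inhibitor

This account rests on a few compounds, and the source may have more. Where it says the series, first, only, none or still open, it means among the compounds named here.

Measured compounds:
- compound 1, `CNc1cc(Oc2ccc(NC(=O)Nc3cccc(C(F)F)c3)cc2)ncn1`: 100 nM
- compound 2, `CNc1cc(Oc2ccc(NC(=O)Nc3cccc(C(F)(F)F)c3)cc2)ncn1`: 40 nM

Both compounds were tested in an assay on isolated protein for inhibition of serine/threonine-protein kinase TNNI3K (Homo sapiens); a higher number here means a weaker inhibitor, a lower number a stronger inhibitor. Among the two numbers, compound 2 has the lowest one, and its nearest neighbour is compound 1, the step between them being a 2.5-fold lower number from compound 1 to compound 2 (0.40 log units; beyond the scatter).

Compound 3, `CNc1cc(Oc2ccc(NC(=O)Nc3cccc(C(C)(C)C)c3)cc2)ncn1`, is not yet measured. It differs from compound 2 in one place: tert-butyl in place of trifluoromethyl on an aromatic carbon of a six-membered aromatic ring of carbon only, meta to a large group.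

Going by the values given here, only one measured step bears on this change, a 2.5-fold lower number from compound 1 to compound 2 (0.40 log units; beyond the scatter), and it altered the same group, but only by the count of fluorine atoms. Among the compounds with values here, the change to compound 3 keeps the size of the group while replacing all fluorine with carbon, which no measured step covers. The expected step, a 1.5-fold higher number from compound 2 to compound 3 (0.18 log units; within the scatter), is therefore small, and may well stay within the scatter. For compound 3 the estimated result in this assay is 60 nM, with a range from 20 nM to 200 nM.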

Compound 3, half-maximal inhibitory concentration: 40 nM
Beside the measured number, compound 3's estimate is 1.5-fold (0.18 log units) above it; low and high end bracket the measured number.
By their numbers in this assay, from the lowest: compounds 2 and 3 (each within the scatter of the next); then compound 1.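

In this assay, putting tert-butyl in place of trifluoromethyl gives no change at the digits printed from compound 2 to compound 3 (within the scatter), so at this place on the ring, fluorine is not needed for the result: a group with the same count of heavy atoms, all of them carbon, serves equally well in this assay. The comparison with the weaker neighbour gives a 2.5-fold lower number from compound 1 to compound 3 (0.40 log units; beyond the scatter), which matches the gap already seen with trifluoromethyl, so among these three compounds, difluoromethyl, the only one of the three groups with a hydrogen on the carbon bound to the ring, stands apart with the higher number. Nothing measured here explains why two groups made of such different atoms score alike, or why difluoromethyl differs from both.

Going by these compounds, what remains open is how much variety this place accepts, for instance whether a smaller methyl, a carboxylic acid, an amine or a longer chain would keep the number where it is. The compounds shown also leave open whether tert-butyl and trifluoromethyl would still match elsewhere on the ring or on a different core.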